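Acetylating the hydroxymethyl: plasma stability of compound 3

The source may hold more compounds than are shown below. What is called first, only, known or untested is meant among the compounds shown, and "the series" means these compounds.

Measured compounds:
- compound 1, `CC(=O)N1CCN(S(=O)(=O)c2ccc(F)cc2)CC1CO`, in an ADME assay on a cell-free system (plasma, Rattus norvegicus, strain Sprague-Dawley) for metabolic stability, read by LC-MS, tested at 1 uM (on this read-out higher numbers stand for a longer-lived compound and lower numbers for a shorter-lived compound), compound 1 gives >= 4 h, which is a limit of the assay rather than a number
- compound 2, `CC(=O)N1CCN(S(=O)(=O)c2ccc(F)cc2)C(CO)C1`, in this assay compound 2 gives >= 4 h, which is likewise a limit rather than a number

Both values sit at the limit of >= 4 h in this assay, at which 2 of the 2 values shown sit, so nothing is known about the real half-life of either beyond that boundary. Compound 1 therefore stands at the limit, and compound 2 stands at the same limit; no order between the two can be read from this. Among the measured compounds shown here, no step between two measured compounds is available, so there is no measured anchor for any structural change.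

Compound 3, `CC(=O)OCC1CN(S(=O)(=O)c2ccc(F)cc2)CCN1C(C)=O`, is not yet measured. It differs from compound 1 by acetyl in place of hydrogen on an oxygen on a saturated carbon. The only firm point is that compound 1 lies at the limit. For the step from compound 1 to compound 3 I expect a shortening of the half-life that goes beyond the usual scatter, so that compound 3 is estimated at an at least 3.3-fold lower number from compound 1 to compound 3 (0.52 log units; beyond the scatter). Compound 3 is expected to show 1.2 h, with a plausible range from 0.3 h to 4 h.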

Compound 3, half-life: 0.5 h
Estimate against measurement, compound 3: 2.4-fold (0.38 log units) above; the measured number falls inside the stated range.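

Before this result, the hydroxymethyl group offered no measured change to learn from, since no step linked any two compounds. Capping its oxygen with an acetyl, the change from hydroxy to acetoxy, now gives a first readable step in this assay: an at least 8.0-fold lower number from compound 1 to compound 3 (0.90 log units; beyond the scatter). So this position is not indifferent to what sits on it, and one small acetyl is enough to bring the half-life down from the top of the assay's range to a value that can actually be read. That step size is only a floor, because the starting point of compound 1 is a limit rather than a number: the limit of >= 4 h in this assay, at which 2 of the 3 values shown sit.

Going by these compounds, what stays open is whether this loss belongs to the acetoxy group in particular or would follow any group placed on that oxygen, a question that a methyl ether, a benzoyl group or an amine in place of the hydroxy could help to settle. On these data alone, it is also open whether the same acetyl on the hydroxymethyl group of compound 2, which sits elsewhere on the shared core, would give a step of similar size.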